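Series notes: acetamido in place of hydroxy

A few compounds are considered here, and "the series" means these few. Any claim that something is new, unique, unknown or untested is made for them only; others in the source may bear on it.

Of the compounds shown here, two have been measured in a physicochemical assay for lipophilicity; on this read-out higher numbers stand for higher lipophilicity and lower numbers for lower lipophilicity. Compound 1 `CC(=O)Nc1ccc(OC(=S)Nc2ccc(Nc3ccc(C(F)(F)F)cc3)cc2)cc1` gives 5.32 in this assay. Within the data shown here, compound 2 `Oc1ccc(OC(=S)Nc2ccc(Nc3ccc(C(Cl)(Cl)Cl)cc3)cc2)cc1` gives 6.79 in this assay and stands highest of the two numbers; its only neighbour is compound 1, whose value lies lower by a gap beyond the scatter. Among the measured compounds shown here, no two measured compounds differ in one place only, so no single step has yet been computed. Compound 3 `CC(=O)Nc1ccc(OC(=S)Nc2ccc(Nc3ccc(C(Cl)(Cl)Cl)cc3)cc2)cc1` remains to be measured in this assay. It differs from compound 2 in one place: acetamido in place of hydroxy on an aromatic carbon. Compound 1 also carries acetamido and gives 5.32 in this assay, while compound 2 gives 6.79 in this assay; the remainder of compound 3 is that of compound 2. A modest step downward from compound 2 is expected, a number 0.39 log units lower from compound 2 to compound 3 (beyond the scatter), somewhat beyond the scatter but far short of the gap to compound 1. Compound 3 is therefore estimated at 6.4, with a range from 5.7 to 7.1.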

Compound 3, partition coefficient: 6.07
For compound 3 the middle estimate is 0.33 log units above the measured one; measured number inside the range.
By their numbers in this assay, from the lowest: compound 1; then compound 3; then compound 2.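

Acetamido in place of hydroxy on an aromatic carbon, para to a large group, now has a single-place reading in this assay: with trichloromethyl held constant, the change gives a number 0.72 log units lower from compound 2 to compound 3 (beyond the scatter) and thus moves the number at this position by a modest step. Compound 3 also links compound 1 and compound 2, which differ in two places: with acetamido held constant, trichloromethyl in place of trifluoromethyl gives a number 0.75 log units higher from compound 1 to compound 3 (beyond the scatter) as a second modest step, so the wide gap between those two compounds divides into two single-place parts, neither of which accounts for it alone. Nothing at hand gives a reason for the size of either step.

The compounds shown leave open whether acetamido in place of hydroxy would give a step of similar size with trifluoromethyl on the other end of the molecule. They also leave open how an amine, a carboxylic acid or an acylamino group with a longer chain would read on the same aromatic carbon.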